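A longer ester chain on the shared core

The source may report more compounds than this note shows. Statements on the series, on what has been measured and on what is new or still open speak of the compounds shown alone.

In a functional assay on A549 cells (Homo sapiens) for inhibition, with a stated time of 48 h, tested at 50 uM (on this read-out higher numbers stand for more inhibition of growth at the one concentration tested and lower numbers for less inhibition of growth), compound 1 `C=C[C@@](C)(/C=C/c1ccc(OC(=O)CCCCC)cc1)CCC=C(C)C` gives 58% while compound 2 `C=C[C@@](C)(/C=C/c1ccc(OC(=O)CCCCCCC)cc1)CCC=C(C)C` gives 15% and compound 3 `C=C[C@@](C)(/C=C/c1ccc(OC(=O)CCCCCCCCC)cc1)CCC=C(C)C` gives 48% on the same read-out. The step of a number 10 percentage points lower from compound 1 to compound 3 (within the scatter) stays within the scatter, whereas the step of a number 33 percentage points higher from compound 2 to compound 3 (beyond the scatter) goes beyond it. Compound 3 therefore belongs with compound 1 in the upper pair of the three and stands clearly apart from compound 2.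

Compound 4 `C=C[C@@](C)(/C=C/c1ccc(OC(=O)CCCCCCCCCCCCCCC)cc1)CCC=C(C)C` differs from compound 3 by hexyl in place of hydrogen on a saturated chain carbon, nine bonds along the chain from a carbonyl carbon and so carries a much longer version of the same ester chain. The measured steps that bear on this change are also chain extensions, and they give no steady direction. The large step of a number 43 percentage points lower from compound 1 to compound 2 (beyond the scatter) is followed by the large step of a number 33 percentage points higher from compound 2 to compound 3 (beyond the scatter) in the opposite direction, so compound 2 goes against any simple trend with chain length. No tested ester has a chain of comparable length, which leaves the outcome open. A moderate fall is tentatively expected, with the estimated step being a number 13 percentage points lower from compound 3 to compound 4 (beyond the scatter) in this assay with wide uncertainty. For compound 4 the estimate is 35% with an expected range from 10% to 60% on this read-out.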

Compound 4, percent growth inhibition at one concentration: 61%
For compound 4 the middle estimate is 26 percentage points below the measured one; measured number outside the range, above it.
By their numbers in this assay, from the lowest: compound 2; then compounds 3, 1 and 4 (each within the scatter of the next, the first and the last beyond it).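

The long chain is tolerated at this position: in this assay the hexyl extension, nine bonds along the chain from a carbonyl carbon, gives a number 13 percentage points higher from compound 3 to compound 4 (beyond the scatter), a modest gain rather than the fall seen in the earlier step from compound 1 to compound 2. Adding decyl to the chain of compound 1, five bonds along the chain from a carbonyl carbon, gives a number 3 percentage points higher from compound 1 to compound 4 (within the scatter), so the esters at the two ends of this series cannot be told apart on this read-out, and growth inhibition is not lost even with the longest chain shown. Compound 2 now stands alone at the bottom, with octyl giving a number 46 percentage points higher from compound 2 to compound 4 (beyond the scatter), which makes it the single exception among the four esters rather than the start of a decline.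

Nothing shown accounts for the low number of compound 2 or for the recovery at longer chain lengths. On these data alone, it also remains open whether the same level of inhibition would hold for a much shorter acetyl ester, for an amide in place of the ester, or for a long chain ending in a carboxylic acid.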